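The compounds below may be only part of what the source reports. "The series", "measured", "known", "first", "only" and "open" are said of these compounds alone.

In a functional assay on cells for positive allosteric modulation of metabotropic glutamate receptor 2 (Homo sapiens), read by scintillation counting and GTPgammaS binding, with a stated time of 30 min (on this read-out higher numbers stand for an effect only at larger amounts of compound and lower numbers for an effect already at smaller amounts), compound 1 `Cc1cc(Oc2ccc(-c3ccn4c(CC5CC5)nnc4c3C(F)(F)F)cc2F)ccn1` gives 56.2 nM, compound 2 `CC(C)Nc1ccc(-c2ccn3c(CC4CC4)nnc3c2Cl)cc1F` gives 224 nM, and compound 3 `CC(C)Nc1ccc(-c2ccn3c(CC4CC4)nnc3c2C(F)(F)F)cc1F` gives 93.3 nM. Compound 3 therefore holds the second highest of the three numbers: the step of a 1.7-fold higher number from compound 1 to compound 3 (0.22 log units; within the scatter) lies within the scatter, whereas the step of a 2.4-fold lower number from compound 2 to compound 3 (0.38 log units; beyond the scatter) is modest but lies beyond it.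

Compound 4 `CC(C)Nc1ccc(-c2ccn3c(CC4CC4)nnc3c2C(F)(F)F)cc1Cl` differs from compound 3 by chloro in place of fluoro on an aromatic carbon. Within the data shown here, no measured step swaps these two halogens at this position; the only halogen exchange seen, a 2.4-fold lower number from compound 2 to compound 3 (0.38 log units; beyond the scatter), sits on the shared core and was modest. The expected step from compound 3 is therefore small, a 1.1-fold higher number from compound 3 to compound 4 (0.03 log units; within the scatter), not beyond the scatter. Compound 4 is estimated at 100 nM, within a range from 45 nM to 220 nM.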

Compound 4, half-maximal effective concentration: 17.4 nM
For compound 4 the middle estimate is 5.7-fold (0.76 log units) above the measured one; measured number below the stated range.
By their numbers in this assay, from the lowest: compound 4; then compounds 1 and 3 (each within the scatter of the next); then compound 2.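

This position on the fluorinated ring, ortho to an isopropylamino group, responds to the identity of its halogen: chloro in place of fluoro gives a 5.4-fold lower number from compound 3 to compound 4 (0.73 log units; beyond the scatter), so the lower number goes with chloro here. Earlier compounds showed a halogen exchange only on the shared core, not at this position. Nothing measured here explains the gain.

From the compounds shown here alone, whether bromo or methyl at this position would lower the number further remains open. So does whether chloro gives the same gain alongside the (2-methylpyridin-4-yl)oxy group of compound 1.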